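A Fluorine Joins the Chlorine on Compound 3

The compounds below may be only part of what the source reports. "The series", "measured", "known", "first", "only" and "open" are said of these compounds alone.

Of the compounds shown here, three with a shared core have been tested in an assay on tissue (HeLa cells) for inhibition of Indoleamine 2,3-dioxygenase 1 (Homo sapiens), read by spectrophotometry; a higher number here means a weaker inhibitor, a lower number a stronger inhibitor. Compound 1 `CCCCOc1cccc(N/C(=N/O)c2ccc3occc3c2)c1` gives only a limit in this assay, > 30000 nM. Compound 2 `O/N=C(/NCc1ccccc1)c1ccc2occc2c1` gives 28200 nM in this assay, and compound 3 `O/N=C(/NCc1cccc(Cl)c1)c1ccc2occc2c1` gives 5800 nM. Compound 3 thus holds the lowest of the two numbers. Among the compounds with values here, the single measured step, a 4.9-fold lower number from compound 2 to compound 3 (0.69 log units; beyond the scatter), came from a chloro in place of hydrogen. Compound 4 `O/N=C(/NCc1ccc(F)c(Cl)c1)c1ccc2occc2c1` differs from compound 3 by fluoro in place of hydrogen on an aromatic carbon. Within the data shown here, no measured step involves a fluoro group; the chloro step is the only halogen addition seen, and adding a second halogen is expected to move the number little, most likely within the scatter. Compound 4 is therefore estimated at 4500 nM, between 1500 nM and 13000 nM, a step of a 1.3-fold lower number from compound 3 to compound 4 (0.11 log units; within the scatter) expected to stay within the scatter.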

Compound 4, half-maximal inhibitory concentration: 17600 nM
Compound 4: the middle estimate sits 3.9-fold (0.59 log units) below what was measured; the whole stated range lies below it.
By their numbers in this assay, from the lowest: compound 3; then compounds 4 and 2 (each within the scatter of the next). At a limit, above all of these: compound 1.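

Adding a second halogen does not repeat the gain from the first: the fluoro group brings a 3.0-fold higher number from compound 3 to compound 4 (0.48 log units; beyond the scatter) and so runs against the earlier chloro step, which was a 4.9-fold lower number from compound 2 to compound 3 (0.69 log units; beyond the scatter) on the same ring. This carbon, ortho to a chloro group and para to a large group, is therefore sensitive to even a single added fluorine atom. Nothing measured here accounts for this reversal.

Going by these compounds, whether the loss belongs to fluoro itself or to this place remains open. An amine or a nitrile on the same carbon, or fluoro on a ring without the chloro group, would help to separate the two.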